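Swapping an Ethyl for a Phenyl on a Shared Core

The source may report more compounds than this note shows. Statements on the series, on what has been measured and on what is new or still open speak of the compounds shown alone.

Compound 1 `Nc1cc(C2CCCCC2)nc2ccc(NC(=O)/C=C/c3ccc(C(F)(F)F)cc3)cc12`: 96 nM
Compound 2 `CCc1cc(N)c2cc(NC(=O)/C=C/c3ccc(C(F)(F)F)cc3)ccc2n1`: 110 nM

Among the compounds with values here, in a functional assay on HEK293 cells for activation of melanin-concentrating hormone receptor 1 (Homo sapiens), read by inositol phosphate accumulation (on this read-out higher numbers stand for an effect only at larger amounts of compound and lower numbers for an effect already at smaller amounts), compound 2 gives 110 nM, the highest of the two numbers so far. Its nearest neighbour is compound 1, which gives 96 nM. The step of a 1.1-fold higher number from compound 1 to compound 2 (0.06 log units; within the scatter) stays within the scatter. Compound 3 `Nc1cc(-c2ccccc2)nc2ccc(NC(=O)/C=C/c3ccc(C(F)(F)F)cc3)cc12` carries phenyl in place of ethyl on an aromatic carbon. Within the data shown here, the only measured step, a 1.1-fold higher number from compound 1 to compound 2 (0.06 log units; within the scatter), exchanged one group for another on that aromatic carbon without moving the number beyond the scatter, so the expected step is a 1.1-fold lower number from compound 2 to compound 3 (0.04 log units; within the scatter), with no movement beyond the scatter. Compound 3 is therefore estimated at 100 nM, between 40 nM and 300 nM.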

Compound 3, half-maximal effective concentration: 6600 nM
The estimate for compound 3 lay 66-fold (1.82 log units) below the measured number, and the stated range ends below it.
By their numbers in this assay, from the lowest: compounds 1 and 2 (each within the scatter of the next); then compound 3.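

The position is not indifferent to what it carries: phenyl in place of ethyl gives a 60-fold higher number from compound 2 to compound 3 (1.78 log units; beyond the scatter), and phenyl in place of cyclohexyl gives a 69-fold higher number from compound 1 to compound 3 (1.84 log units; beyond the scatter), so much more of compound 3 is needed for the same effect. Ethyl and cyclohexyl stay within the scatter of each other, so a six-membered ring alone does not go with this loss, whereas the aromatic phenyl does. No measurement here accounts for the difference. Open, going by these compounds, is whether a pyridine ring, or a phenyl carrying a methoxy group, behaves like phenyl or like cyclohexyl.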